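The source may report more compounds than this note shows. Statements on the series, on what has been measured and on what is new or still open speak of the compounds shown alone.

Measured compounds:
compound 1, `Oc1ccc(-c2cc(-c3cccc(Cl)c3)nc(-c3ccccn3)c2)cc1`, 28200 nM
compound 2, `Oc1ccc(-c2cc(-c3ccc(Cl)cc3)nc(-c3ccccn3)c2)cc1`, 21300 nM

In a functional assay on HCT-15 cells (Homo sapiens) for cytotoxicity, read by CCK-8 assay and cell counting, with a stated time of 2 days (a higher number here means a weaker inhibitor, a lower number a stronger inhibitor), compound 1 gives the highest of the two numbers, but compound 2 sits close to it: a 1.3-fold lower number from compound 1 to compound 2 (0.12 log units; within the scatter), so the two cannot be told apart. The unmeasured compound 3, `Oc1ccc(-c2cc(-c3cccc(Cl)c3)nc(-c3ccco3)c2)cc1`, differs from compound 1 at one site: furan-2-yl in place of pyridin-2-yl on an aromatic carbon. Going by the values given here, the only measured step, from compound 1 to compound 2, concerns the chlorophenyl group and not the group that changes here, so it says nothing about how replacing pyridin-2-yl with furan-2-yl next to the ring nitrogen will turn out. With no guide in the data, the expected step of a 1.1-fold higher number from compound 1 to compound 3 (0.03 log units; within the scatter) is small, with no preferred direction, and a wide range is kept. Compound 3 is therefore estimated at 30000 nM in this assay, with a range from 8000 nM to 100000 nM.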

Compound 3, half-maximal inhibitory concentration: 8020 nM
Compound 3: the middle estimate sits 3.7-fold (0.57 log units) above what was measured; the range from low to high includes it.
By their numbers in this assay, from the lowest: compound 3; then compounds 2 and 1 (each within the scatter of the next).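

Within this assay the position next to the ring nitrogen responds to its group: furan-2-yl in place of pyridin-2-yl gives a 3.5-fold lower number from compound 1 to compound 3 (0.55 log units; beyond the scatter) and so provides the first change in this set that lies beyond the scatter, though only a modest one. The two groups each carry one hetero atom and one hydrogen-bond acceptor, yet they differ in ring size and in that atom, oxygen for nitrogen, so the result shows that swapping one aromatic ring for the other here is not neutral. Nothing available explains the lower number of compound 3.

From the compounds shown here alone, this single swap changes ring size and hetero atom together, so their separate contributions remain open. Also open, going by these compounds, is how a thiophen-2-yl ring, an amine or a carboxylic acid would fare at this position, and whether furan-2-yl would give a similar step alongside the 4-chlorophenyl group of compound 2.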